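A Methoxy Group Added to a Weak Inhibitor

This account rests on a few compounds, and the source may have more. Where it says the series, first, only, none or still open, it means among the compounds named here.

Compound 1 `C=C1CC[C@@H]2[C@](C)(CNCc3cccs3)[C@H](O)CC[C@@]2(C)[C@@H]1/C=C/C1=CCOC1=O` and compound 2 `C=C1CC[C@H]2[C@@](C)(CC[C@@H](O)[C@@]2(C)C(=O)NCc2ccccc2)[C@@H]1/C=C/C1=CCOC1=O` were both tested in a functional assay on BMMC cells (Mus musculus, strain C57BL/6) for inhibition, with stated times of 5 days and 48 h; a lower number here means a stronger inhibitor, a higher number a weaker inhibitor. Within the data shown here, compound 1 gives 1070 nM, and compound 2 gives 19400 nM, the higher of the two numbers; the single measured step, an 18-fold higher number from compound 1 to compound 2 (1.26 log units; beyond the scatter), separates them. Compound 3 `C=C1CC[C@H]2[C@@](C)(CC[C@@H](O)[C@@]2(C)C(=O)NCc2ccc(OC)cc2)[C@@H]1/C=C/C1=CCOC1=O` differs from compound 2 by methoxy in place of hydrogen on an aromatic carbon. Among the measured compounds shown here, no measured step covers this kind of change; the one known step concerns a different part of the molecule and offers no guide here. A step within the usual scatter is therefore expected, a 1.0-fold lower number from compound 2 to compound 3 (0.01 log units; within the scatter). Compound 3 is estimated at 19000 nM, within 6000 nM to 60000 nM.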

Compound 3, half-maximal inhibitory concentration: 6530 nM
Estimate against measurement, compound 3: 2.9-fold (0.46 log units) above, within the range that was stated.
By their numbers in this assay, from the lowest: compound 1; then compound 3; then compound 2.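

Turning benzyl into 4-methoxybenzyl gives a 3.0-fold lower number from compound 2 to compound 3 (0.47 log units; beyond the scatter) in this assay and shows that this aromatic ring accepts an added group, with the number moving modestly towards a stronger inhibitor. Among these compounds, the earlier step concerned a different part of the molecule, so this is the first view of a change on this ring. Nothing available explains the shift. Going by these compounds, whether a chlorine atom, a hydroxyl group or an amine at this place would move the number further stays open. So does whether methoxy would have a similar effect on other aromatic rings in the series, such as the thiophene of compound 1.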